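This account rests on a few compounds, and the source may have more. Where it says the series, first, only, none or still open, it means among the compounds named here.

Compound 1 `COC1(Cc2cccc(Cl)c2)CCN(c2ccc(C(=O)NS(=O)(=O)c3ccc(N[C@H](CCN(C)C)CSc4ccccc4)c([N+](=O)[O-])c3)cc2)CC1` and compound 2 `CN(C)CC[C@H](CSc1ccccc1)Nc1ccc(S(=O)(=O)NC(=O)c2ccc(N3CCC(=Cc4ccccc4C(F)(F)F)CC3)cc2)cc1[N+](=O)[O-]` share one core. In an assay on isolated protein for displacement of a labelled ligand from Apoptosis regulator Bcl-2 (Homo sapiens), read by fluorescence polarization (on this read-out higher numbers stand for weaker inhibition and lower numbers for stronger inhibition), compound 1 gives 1.8 nM, and compound 2 gives 2 nM, the higher of the two numbers, although the gap between them lies within the usual scatter. Compound 3 `CN(C)CC[C@H](CSc1ccccc1)Nc1ccc(S(=O)(=O)NC(=O)c2ccc(N3CCC(=Cc4cccnc4)CC3)cc2)cc1[N+](=O)[O-]` has not yet been measured. It differs from compound 2 by pyridin-3-yl in place of 2-(trifluoromethyl)phenyl on a double-bonded chain carbon bound to a double-bonded ring carbon. For the measured compounds named here, no step between two measured compounds is available, so nothing here shows how such a change has played out before. A modest step toward a higher number, a 2.0-fold higher number from compound 2 to compound 3 (0.30 log units; within the scatter), is expected. In this assay compound 3 is estimated at 4 nM, with a range from 1.5 nM to 12 nM.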

Compound 3, inhibition constant: 68 nM
The estimate for compound 3 lay 17-fold (1.23 log units) below the measured number; measured number outside the range, above it.
By their numbers in this assay, from the lowest: compounds 1 and 2 (each within the scatter of the next); then compound 3.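

Pyridin-3-yl in place of 2-(trifluoromethyl)phenyl on a double-bonded chain carbon bound to a double-bonded ring carbon brings a 34-fold higher number from compound 2 to compound 3 (1.53 log units; beyond the scatter) in this assay and so shows that this position does not tolerate every aromatic ring. The earlier compounds shown here, which differ in more than one place, could not show this sensitivity. Nothing available bears on the reason for this weakening. On these data alone, whether the ring nitrogen or the loss of trifluoromethyl matters more remains open; a plain phenyl ring, or a pyridine ring carrying trifluoromethyl, would separate the two.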